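The compounds below may be only part of what the source reports. "The series", "measured", "known", "first", "only" and "open" are said of these compounds alone.

Working notes on the series. The shared core is that of compound 1 `CCOC(=O)C1=C(Nc2ccccc2)S/C(=C\c2ccccc2)C1=O`. In a functional assay on MCF7 cells (Homo sapiens) for inhibition, read by MTT assay, with a stated time of 72 h, tested at 10 uM (on this read-out higher numbers stand for more inhibition at the one concentration tested (going by the name of the read-out) and lower numbers for less inhibition), compound 1 gives 23.6%, the lower of the two numbers recorded so far. Among the measured compounds shown here, the only other measured compound, compound 2 `CCOC(=O)C1=C(Nc2ccccc2Br)S/C(=C\c2ccc[nH]2)C1=O`, gives 29.4% in this assay; the gap to compound 1 lies within the scatter, so the two read as equivalent. For the measured compounds named here, compound 2 differs from compound 1 in more than one place, and no single step between them is computed, so nothing beyond the two values themselves can be said of that pair.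

Compound 3 `CCOC(=O)C1=C(Nc2ccccc2)S/C(=C\c2cc3ncccc3[nH]2)C1=O` has not yet been measured in this assay. Relative to compound 1 the change is a group of 9 heavy atoms (7 carbon, 2 nitrogen; one five-membered aromatic ring with 1 hetero atom, one six-membered aromatic ring with 1 hetero atom) in place of a group of 6 heavy atoms (6 carbon; one six-membered aromatic ring of carbon only), on a double-bonded chain carbon bound to a double-bonded ring carbon. Going by the values given here, no measured pair carries this change, so there is no step to lean on, and the two values present point in no direction. The expected step is a number 4.4 percentage points higher from compound 1 to compound 3 (within the scatter), a shift not expected to go beyond the scatter. Compound 3 is expected to give 28% in this assay, within a range from 12% to 48%.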

Compound 3, a percentage reported as inhibition, at one concentration (the size of the read-out at that concentration, not a potency): 42.2%
The estimate for compound 3 lay 14.2 percentage points below the measured number; the measured number falls inside the stated range.
By their numbers in this assay, from the lowest: compounds 1 and 2 (each within the scatter of the next); then compound 3.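

On a double-bonded chain carbon bound to a double-bonded ring carbon, putting the group of 9 heavy atoms in place of phenyl gives a number 18.6 percentage points higher from compound 1 to compound 3 (beyond the scatter) in this assay, a modest step and the only one in the series that can be read so far. It shows that the read-out responds to a change at this place, which compound 1 and compound 2 could not show, as they differ in more than one place. Nothing at hand bears on why this step occurs.

The change swaps one aromatic ring of carbon only for a five-membered and a six-membered aromatic ring, each with a hetero atom, and adds a hydrogen-bond donor and a hydrogen-bond acceptor, and the compounds shown do not separate these parts from one another. Open, therefore, is what a single pyridyl ring, an indolyl group with no nitrogen in its six-membered ring, or a saturated piperidine ring would give at this place on the core of compound 1.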